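The compounds below may be only part of what the source reports. "The series", "measured", "known", "first", "only" and "open" are said of these compounds alone.

Compound 1, `COc1ccc(C2CC(Nc3nc4ccc([N+](=O)[O-])cc4s3)=NN2C(C)=O)cc1`, in a functional assay on the whole organism (Hindlimb, strain albino) with Mus musculus as the target, in the maximal electroshock model, with a stated time of 0.5 h; on this read-out lower numbers stand for an effect already at smaller amounts and higher numbers for an effect only at larger amounts of compound: 145 umol/kg
Compound 2, `CC(=O)N1N=C(Nc2nc3ccc([N+](=O)[O-])cc3s2)CC1c1ccc(O)cc1`: 162 umol/kg
Compound 3, `COc1ccc(/C=C/C(=O)Nc2nc3ccc(Cl)cc3s2)cc1`: 259 umol/kg

Among the compounds with values here, the one change seen twice in this set is hydrogen in place of methyl on an oxygen on an aromatic ring. Between compound 1 and compound 2 it made a 1.1-fold higher number from compound 1 to compound 2 (0.05 log units; within the scatter), so the two numbers sit within the scatter of each other. Compound 3 carries a different core; the difference between the core of compound 1 and the core of compound 3 is not broken down here. Compound 4, `O=C(/C=C/c1ccc(O)cc1)Nc1nc2ccc(Cl)cc2s1`, is drawn from compound 3 by the same change, (hydrogen in place of methyl on an oxygen on an aromatic ring), at a place described in the same words as in the earlier pair. The step expected from compound 3 to compound 4 is estimated at a 1.1-fold higher number from compound 3 to compound 4 (0.03 log units; within the scatter) because a 1.1-fold higher number from compound 1 to compound 2 (0.05 log units; within the scatter) barely moved the number. Compound 4 is therefore expected to give 280 umol/kg in this assay, with a range from 150 umol/kg to 520 umol/kg.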

Compound 4, dose for half-maximal effect: 322 umol/kg
Estimate against measurement, compound 4: 1.2-fold (0.06 log units) below; low and high end bracket the measured number.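

In this assay, going from methoxy to hydroxy gave a 1.2-fold higher number from compound 3 to compound 4 (0.09 log units; within the scatter), so on this core too the two numbers sit within the scatter of each other. The step carried over between the two cores without a difference that can be told apart: the same change on two cores in this assay, a 1.1-fold higher number (0.05 log units; within the scatter) from compound 1 to compound 2 and a 1.2-fold higher number (0.09 log units; within the scatter) from compound 3 to compound 4, 1.1-fold (0.05 log units) apart, within the scatter of two such steps. This shows that the change left the number in place on these two pairs, but it does not show that the same would hold on any other core, nor does it show what either group contributes to the effect.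

The compounds shown leave open what a longer chain on that oxygen, or an amine in place of it, would do to the number.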